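A few compounds are considered here, and "the series" means these few. Any claim that something is new, unique, unknown or untested is made for them only; others in the source may bear on it.

Measured compounds:
Compound 1, `N=C(N)NS(=O)(=O)c1ccc(N/C(S)=N\c2ccnc3cc(C(F)(F)F)ccc23)cc1` — in a functional assay on MDA-MB-231 cells (Homo sapiens) for antiproliferative activity, read by sulforhodamine B assay, with a stated time of 48 h (on this read-out higher numbers stand for weaker inhibition and lower numbers for stronger inhibition), compound 1 gives "not active" (no number reported).
Compound 2, `O=S(=O)(Nc1ccccn1)c1ccc(N/C(S)=N\c2ccnc3cc(C(F)(F)F)ccc23)cc1` — in this assay compound 2 gives 49300 nM.
Compound 3, `O=S(=O)(Nc1ncccn1)c1ccc(N/C(S)=N\c2ccnc3cc(C(F)(F)F)ccc23)cc1` — in this assay compound 3 gives 45200 nM.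

Going by the values given here, compound 3 has the lowest of the two reported numbers, but the only measured step, a 1.1-fold lower number from compound 2 to compound 3 (0.04 log units; within the scatter), lies within the scatter, so compounds 2 and 3 cannot be told apart on these data, and compound 1 has no number at all. Compound 4, `Cc1ccnc(NS(=O)(=O)c2ccc(N/C(S)=N\c3ccnc4cc(C(F)(F)F)ccc34)cc2)n1`, keeps the shared core of compound 3 and differs from it by methyl in place of hydrogen on an aromatic carbon. Among the compounds with values here, no measured step touches this kind of change: the single step available exchanges one ring for another on the sulfonamide nitrogen and leaves the number essentially unchanged. With nothing pointing either way, the expected step of a 1.0-fold lower number from compound 3 to compound 4 (0.00 log units; within the scatter) from compound 3 to compound 4 is none beyond the scatter. Compound 4 is therefore estimated at 45000 nM in this assay, with a range from 15000 nM to 120000 nM, the wide range reflecting how little the data constrain it.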

Compound 4, half-maximal inhibitory concentration: 29800 nM
Estimate against measurement, compound 4: 1.5-fold (0.18 log units) above; the range from low to high includes it.
By their numbers in this assay, from the lowest: compounds 4, 3 and 2 (each within the scatter of the next).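

Placing a methyl on this ring carbon, which turns pyrimidin-2-yl into 4-methylpyrimidin-2-yl, gives the first reading of this position in this assay (a 1.5-fold lower number from compound 3 to compound 4 (0.18 log units; within the scatter)), and the number does not move beyond the scatter. The comparison with the pyridin-2-yl group on the same sulfonamide nitrogen (a 1.7-fold lower number from compound 2 to compound 4 (0.22 log units; within the scatter)) also stays within the scatter, so this assay does not separate the three ring groups carried by compound 2, compound 3 and compound 4. Nothing available explains the small difference seen here.

The compounds shown leave open whether an amine, a methoxy group or a longer chain at this position would shift the number beyond the scatter. They also do not show whether a methyl on another carbon of this ring would do so.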